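Notes on a dihydroxy amide: removing one hydroxy

The compounds below may be only part of what the source reports. "The series", "measured", "known", "first", "only" and "open" are said of these compounds alone.

The series is read in an ADME assay on HEK293 cells (Homo sapiens) for cytotoxicity, read by resazurin assay, with a stated time of 24 h; on this read-out higher numbers stand for lower toxicity in this test and lower numbers for higher toxicity in this test. Compound 1 `COc1cc(O)c(C(=O)O)c(CCc2ccc3ccccc3c2)c1` gives 65000 nM. Compound 2 `CCN(CC)C(=O)c1c(O)cc(O)cc1CCc1ccc2ccccc2c1` gives 30600 nM, the lower of the two numbers, separated from compound 1 by a gap beyond the usual scatter. Compound 3 `O=C(O)c1c(O)cccc1CCc1ccccc1` reaches only the limit of this assay, > 100000 nM; the limit of > 100000 nM in this assay, at which 1 of the 3 values shown sits, records that one of the three values sits there.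

Compound 4 `CCN(CC)C(=O)c1c(O)cccc1CCc1ccc2ccccc2c1` is not yet measured. It differs from compound 2 by hydrogen in place of hydroxy on an aromatic carbon. Going by the values given here, no step between measured compounds that differ in one place is available, so the size of this move is open; in this assay a shift of modest size, if any, is expected, not clearly beyond the scatter, with the direction more likely toward a higher number. Compound 3, which also carries a single hydroxy on its core, sits at the limit > 100000 nM, and this leans the guess upward. Compound 4 is estimated at 45000 nM, with a range from 18000 nM to 110000 nM. That estimate means an expected step of a 1.5-fold higher number from compound 2 to compound 4 (0.17 log units; within the scatter).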

Compound 4, half-maximal cytotoxic concentration: > 100000 nM
Compound 4: a limit, no number (the forecaster's own chance of this, stated with the estimate: 30%); middle value at least 2.2-fold (0.34 log units) away from the limit.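

In this assay, going by these compounds alone, hydrogen in place of the hydroxy para to a diethylcarbamoyl group gives an at least 3.2-fold higher number from compound 2 to compound 4 (0.51 log units; beyond the scatter), the first one-place step, and it shows that this position bears on the read-out beyond the scatter. Compound 4 gives > 100000 nM, a limit of the assay and not a number. The step therefore fixes only a lower bound on the size of this change, and the limit now holds more than one compound of the series: the limit of > 100000 nM in this assay, at which 2 of the 4 values shown sit.

Still open, on these data alone, is whether a methoxy, an amine or a fluorine at this position would read like compound 2 or like compound 4. Also open, as far as these compounds go, is how the same hydroxy removal would read with a carboxylic acid in place of the diethylcarbamoyl group.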